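Removing the sulfonyl-amino group from the spiro-core acid

The source may report more compounds than this note shows. Statements on the series, on what has been measured and on what is new or still open speak of the compounds shown alone.

Measured compounds:
- compound 1, `Cc1noc(C)c1S(=O)(=O)N[C@@H](CCC(=O)N1CCC2(CC1)CCN(c1ccncc1)CC2)C(=O)O`: 21 nM
- compound 2, `Cc1noc(C)c1S(=O)(=O)N[C@@H](CNC(=O)N1CCC2(CC1)CCN(c1ccncc1)CC2)C(=O)O`: 39 nM

Both compounds were tested in a functional assay for inhibition, with Homo sapiens as the target; a higher number here means a weaker inhibitor, a lower number a stronger inhibitor. Compound 1 gives 21 nM in this assay and has the lowest number of the two; compound 2, at 39 nM, sits within the scatter of it, so the two cannot be ordered.

Compound 3, `O=C(O)CCCC(=O)N1CCC2(CC1)CCN(c1ccncc1)CC2`, has not yet been measured in this assay. It differs from compound 1 by hydrogen in place of ((3,5-dimethyl-1,2-oxazol-4-yl)sulfonyl)amino on a saturated chain carbon bound to a carbonyl carbon and a saturated chain carbon. Among the compounds with values here, with no measured pair showing this change, the expectation rests on the size of what leaves: a large group is replaced by a hydrogen atom, and a clear loss is expected. The step from compound 1 is estimated as a 29-fold higher number from compound 1 to compound 3 (1.46 log units; beyond the scatter), well beyond the scatter. Compound 3 is therefore expected to give about 600 nM in this assay, within a range of 100 nM to 4000 nM.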

Compound 3, half-maximal inhibitory concentration: 5080 nM
The estimate for compound 3 lay 8.5-fold (0.93 log units) below the measured number, and the stated range ends below it.
By their numbers in this assay, from the lowest: compounds 1 and 2 (each within the scatter of the next); then compound 3.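

Taking the ((3,5-dimethyl-1,2-oxazol-4-yl)sulfonyl)amino group off the saturated chain carbon gives a 240-fold higher number from compound 1 to compound 3 (2.38 log units; beyond the scatter) in this assay and is the first change here to move the number beyond the scatter. Compound 1 and compound 2 both carry this group, so neither could show what its presence is worth; this step shows that most of the strength of compound 1 goes with it, although compound 3, which keeps the core and the carboxylic acid, still gives 5080 nM in this assay as a finite number. No measurement at hand accounts for the size of this loss.

On these data alone, it remains open whether something smaller at this carbon, such as an amine or an acetylamino group, would recover part of the loss. Within the data shown here, it is also open whether a sulfonylamino group bearing a phenyl ring would serve as well as the one in compound 1.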